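Swapping a Ring-Bearing Chain End for a Small Amine

The compounds below may be only part of what the source reports. "The series", "measured", "known", "first", "only" and "open" are said of these compounds alone.

Of the compounds shown here, three built on one shared core have so far been measured in a functional assay on cells for antagonist activity at C-X-C chemokine receptor type 4 (Homo sapiens), read by fluorescence and calcium flux, with stated times of 25 min and 90 s; on this read-out higher numbers stand for weaker inhibition and lower numbers for stronger inhibition. Compound 1 `c1cncc(CNCCCCN(C[C@H]2Cc3ccccc3CN2)[C@H]2CCCc3cccnc32)c1` gives 15.3 nM. Compound 2 `c1ccc2c(c1)CN[C@@H](CN(CCCCNCC1CCOCC1)[C@H]1CCCc3cccnc31)C2` gives 52.9 nM, and compound 3 `NCc1ccccc1CN(C[C@H]1Cc2ccccc2CN1)[C@H]1CCCc2cccnc21` gives 50.8 nM. Compound 2 stands highest of the three numbers: the step of a 3.5-fold higher number from compound 1 to compound 2 (0.54 log units; beyond the scatter) lies beyond the scatter, whereas compound 2 and compound 3 sit within the scatter of each other, as the step of a 1.0-fold lower number from compound 2 to compound 3 (0.02 log units; within the scatter) shows.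

Compound 4 `CC(C)(N)CCCN(C[C@H]1Cc2ccccc2CN1)[C@H]1CCCc2cccnc21` has not yet been measured. It differs from compound 2 in one place: a group of 4 heavy atoms (3 carbon, 1 nitrogen; no ring) in place of a group of 9 heavy atoms (7 carbon, 1 nitrogen, 1 oxygen; one six-membered non-aromatic ring with 1 hetero atom), on a saturated chain carbon, three bonds along the chain from an amine nitrogen. The group that enters is small and carries no ring.

Within the data shown here, two measured steps touch this region of the chain. The step of a 3.3-fold higher number from compound 1 to compound 3 (0.52 log units; beyond the scatter) and the step of a 3.5-fold higher number from compound 1 to compound 2 (0.54 log units; beyond the scatter) were both modest, and the step of a 1.0-fold lower number from compound 2 to compound 3 (0.02 log units; within the scatter), which also removed the oxane-bearing piece, stayed within the scatter. Among the measured compounds shown here, no measured step introduces a 1-amino-1-methylethyl group, so the direction is uncertain. Compound 4 is therefore expected to show only a small step, a 1.3-fold lower number from compound 2 to compound 4 (0.12 log units; within the scatter), most likely within the scatter. The estimate for compound 4 in this assay is 40 nM, with a range from 15 nM to 110 nM.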

Compound 4, half-maximal inhibitory concentration: 24.6 nM
Estimate against measurement, compound 4: 1.6-fold (0.21 log units) above; the measured number falls inside the stated range.
By their numbers in this assay, from the lowest: compounds 1 and 4 (each within the scatter of the next); then compounds 3 and 2 (each within the scatter of the next).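

In this assay, the small 1-amino-1-methylethyl group, which carries no ring, does better than the larger ring-bearing chain end of compound 2: a 2.2-fold lower number from compound 2 to compound 4 (0.33 log units; beyond the scatter) is a modest step beyond the scatter, and a 2.1-fold lower number from compound 3 to compound 4 (0.31 log units; beyond the scatter) is a step of similar size in the same direction from a different chain end. The pyridin-3-yl end of compound 1 also offers no measurable advantage over this small group, since a 1.6-fold higher number from compound 1 to compound 4 (0.21 log units; within the scatter) stays within the scatter, so among these compounds a ring at the end of the chain is not needed to reach the lowest numbers, even though compound 1 carries one and does just as well. Nothing measured here explains why the small group performs this way.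

The compounds shown leave open what the methyl groups of the 1-amino-1-methylethyl group contribute, a question that a plain aminomethyl group at this place would address. They also leave open whether the amine itself matters, which could be tested with a hydroxyl group or a carboxylic acid in its stead.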